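The source may report more compounds than this note shows. Statements on the series, on what has been measured and on what is new or still open speak of the compounds shown alone.

Of the compounds shown here, three have been measured in an ADME assay on HepG2 cells (Homo sapiens) for cytotoxicity, read by MTT assay, with a stated time of 72 h; on this read-out lower numbers stand for higher toxicity in this test and higher numbers for lower toxicity in this test. Compound 1 `CC1(c2ccc(-c3ccco3)cc2)CC(S(=O)(=O)c2ccc(F)cc2)=C(c2ccc(/C(N)=N\O)cc2)O1` gives 7010 nM, the lowest of the three numbers, so it is the most toxic of them here. Compound 2 `CC1(Cc2ccccc2)CC(S(=O)(=O)c2c(F)cccc2F)=C(c2ccc(/C(N)=N\O)cc2)O1` gives 91400 nM and compound 3 `CCC1(c2ccccc2OC)CC(S(=O)(=O)c2ccc(F)cc2)=C(c2ccc(/C(N)=N\O)cc2)O1` gives 27000 nM; each of these two stands beyond the scatter from compound 1. Compound 4 `CC1(c2ccc(-c3cccc(/C(N)=N\O)c3)cc2)CC(S(=O)(=O)c2ccc(F)cc2)=C(c2ccc(/C(N)=N\O)cc2)O1` has not yet been measured. It differs from compound 1 at one place: a group of 10 heavy atoms (7 carbon, 2 nitrogen, 1 oxygen; one six-membered aromatic ring of carbon only) in place of a group of 5 heavy atoms (4 carbon, 1 oxygen; one five-membered aromatic ring with 1 hetero atom), on an aromatic carbon. Among the compounds with values here, no measured pair shows this change, so its effect can only be guessed; a modest rise in the number, towards lower toxicity, seems as likely as a step within the scatter. The estimate for compound 4 in this assay is 12000 nM, within a range from 4000 nM to 40000 nM, which means an expected step of a 1.7-fold higher number from compound 1 to compound 4 (0.23 log units; within the scatter).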

Compound 4, half-maximal cytotoxic concentration: 19000 nM
Compound 4: the middle estimate sits 1.6-fold (0.20 log units) below what was measured, and the stated range covers the measured number.
By their numbers in this assay, from the lowest: compound 1; then compounds 4 and 3 (each within the scatter of the next); then compound 2.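

At this aromatic carbon, para to a large group, replacing furan-2-yl with the larger group built on a six-membered aromatic ring of carbon only gives a 2.7-fold higher number from compound 1 to compound 4 (0.43 log units; beyond the scatter) in this assay and so a modest move towards lower toxicity in this test. The position therefore accepts this larger group, with its hydrogen-bond donors, without the number falling. Nothing available explains this step. Whether the ring alone or the group it carries accounts for the step stays open; a plain phenyl or a phenyl bearing a carboxylic acid at this place would help separate the two.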